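A Second Methyl Step in a Sulfonamide Series

The source may hold more compounds than are shown below. What is called first, only, known or untested is meant among the compounds shown, and "the series" means these compounds.

In a functional assay on J774 cells (Mus musculus) for cytotoxicity, read by resazurin assay, with a stated time of 72 h (on this read-out higher numbers stand for weaker inhibition and lower numbers for stronger inhibition), three compounds have been measured so far:
compound 1, `O=S(=O)(Nc1cccc(CO)c1)c1ccc(-c2ccccc2)cc1`, gives 2200 nM;
compound 2, `Cc1ccc(-c2ccc(S(=O)(=O)Nc3cccc(CO)c3)cc2)cc1`, gives 1200 nM;
compound 3, `O=S(=O)(Nc1cccc(CO)c1)c1ccc(-c2ccc(F)cc2F)cc1`, gives 300 nM.

Compound 2 differs from compound 1 by methyl in place of hydrogen on an aromatic carbon, and this change gives a 1.8-fold lower number from compound 1 to compound 2 (0.26 log units; within the scatter). The core of compound 3 differs from that of compound 1 by 2,4-difluorophenyl in place of phenyl on an aromatic carbon, a change that gives a 7.3-fold lower number from compound 1 to compound 3 (0.87 log units; beyond the scatter); between compound 2 and compound 3 there is a 4.0-fold lower number from compound 2 to compound 3 (0.60 log units; beyond the scatter).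

Compound 4, `Cc1cc(S(=O)(=O)Nc2cccc(CO)c2)ccc1-c1ccc(F)cc1F`, has not yet been measured. It differs from compound 3 by methyl in place of hydrogen on an aromatic carbon. Among the compounds with values here, this is the same kind of change as the one from compound 1 to compound 2, but not the same: there the methyl entered para to a large group, whereas here it enters ortho to a 2,4-difluorophenyl group and meta to a large group. The earlier methyl step gave a 1.8-fold lower number from compound 1 to compound 2 (0.26 log units; within the scatter), which lies within the scatter. On that basis compound 4 is expected to show a 1.2-fold lower number from compound 3 to compound 4 (0.08 log units; within the scatter). The estimate for compound 4 is therefore 250 nM, expected to fall between 120 nM and 600 nM.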

Compound 4, half-maximal inhibitory concentration: 100 nM
Estimate against measurement, compound 4: 2.5-fold (0.40 log units) above; the measured number lies below the stated range.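

In this assay, methyl in place of hydrogen on an aromatic carbon gives a 3.0-fold lower number from compound 3 to compound 4 (0.48 log units; beyond the scatter). Set beside the earlier methyl step, this result does not stand apart from it: the same change on two cores in this assay, a 1.8-fold lower number (0.26 log units; within the scatter) from compound 1 to compound 2 and a 3.0-fold lower number (0.48 log units; beyond the scatter) from compound 3 to compound 4, 1.6-fold (0.21 log units) apart, within the scatter of two such steps The two steps therefore give no sign that this change behaves differently on these two cores, even though the methyl enters at a different place on each, but they do not show that one fixed size carries over, since only the newer step lies beyond the scatter and two pairs cannot support a rule for other cores in the series.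

The compounds shown leave open whether an ethyl, a methoxy or a chlorine in place of this methyl would give a similar step on the core of compound 3. They also leave open how the methyl step would behave if the hydroxymethyl group of the shared core gave way to an amine or a carboxylic acid.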